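Benzimidazole in place of aminohydroxyimidazole on the ether chain

The compounds below may be only part of what the source reports. "The series", "measured", "known", "first", "only" and "open" are said of these compounds alone.

Measured compounds:
compound 1, `CCO/C(O)=C1\C(COCCn2c(C)nc(C)c2C)=NC(C)=C(C(=O)OC)C1c1ccccc1Cl`: 5.01 nM
compound 2, `CCO/C(O)=C1\C(COCCn2c(N)cnc2O)=NC(C)=C(C(=O)OC)C1c1ccccc1Cl`: 158 nM

Two compounds share a core and differ only in the ring carried on the ether chain. In a functional assay (aorta) with Rattus norvegicus as the target (on this read-out lower numbers stand for stronger inhibition and higher numbers for weaker inhibition), compound 1 gives 5.01 nM, and compound 2 gives 158 nM. For the measured compounds named here, compound 2 therefore stands highest of the two numbers, with a 32-fold higher number from compound 1 to compound 2 (1.50 log units; beyond the scatter) separating it from its only neighbour.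

Compound 3, `CCO/C(O)=C1\C(COCCn2cnc3ccccc32)=NC(C)=C(C(=O)OC)C1c1ccccc1Cl`, has not yet been measured. The change from compound 2 is 1H-benzimidazol-1-yl in place of 5-amino-2-hydroxy-1H-imidazol-1-yl on a saturated chain carbon, two bonds along the chain from an oxygen on a saturated carbon. Going by the values given here, the one measured step that bears on it is the exchange of the ring at this same place, which gave a 32-fold higher number from compound 1 to compound 2 (1.50 log units; beyond the scatter), a large shift. Among the compounds with values here, the present change again replaces the 5-amino-2-hydroxy-1H-imidazol-1-yl group, this time with a 1H-benzimidazol-1-yl group; since no measured compound carries this group, the size of its effect is not known from the data. Within the data shown here, on the basis of the one relevant step, a lower number than compound 2 is expected, and compound 3 is estimated at 12 nM, with a range from 3 nM to 50 nM, which is expected to mean a 13-fold lower number from compound 2 to compound 3 (1.12 log units; beyond the scatter).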

Compound 3, half-maximal inhibitory concentration: 20 nM
Beside the measured number, compound 3's estimate is 1.7-fold (0.22 log units) below it; the range from low to high includes it.
By their numbers in this assay, from the lowest: compound 1; then compound 3; then compound 2.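

In this assay, 1H-benzimidazol-1-yl in place of 5-amino-2-hydroxy-1H-imidazol-1-yl gives a 7.9-fold lower number from compound 2 to compound 3 (0.90 log units; beyond the scatter), so this position on the ether chain accepts a group with an added six-membered aromatic ring of carbon only and no hydrogen-bond donors, and the number still falls. The same benzimidazole set against 2,4,5-trimethyl-1H-imidazol-1-yl gives a 4.0-fold higher number from compound 1 to compound 3 (0.60 log units; beyond the scatter), which places it between the two earlier groups and leaves compound 1 with the lowest number of the three, so the exchanges at this one place now span a graded series rather than a single large shift. Nothing among the available data accounts for this order, and the three compounds alone cannot assign it to any one feature of the groups.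

The compounds shown leave open whether the amine or the hydroxyl of the group in compound 2 goes with its higher number, as neither appears alone on the ring. They also leave open how an unsubstituted imidazole, methyl groups on the benzimidazole, or a propyl chain in place of the ethyl chain would read at this position.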